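This account rests on a few compounds, and the source may have more. Where it says the series, first, only, none or still open, it means among the compounds named here.

Working notes on the benzyloxy-acetophenone series.

Of the compounds shown here, two have numbers so far. Compound 1 `CC(=O)c1ccc(OCc2ccc(Cl)cc2)cc1` in an assay on isolated protein for inhibition of Amine oxidase [flavin-containing] B (Homo sapiens), read by Amplex Red, with a stated time of 15 min (a lower number here means a stronger inhibitor, a higher number a weaker inhibitor), gives 63.2 nM. Compound 2 `CC(=O)c1cccc(OCc2ccc(C)cc2)c1` in this assay gives 140 nM, the higher of the two numbers; the gap between compound 1 and compound 2 lies beyond the usual scatter, so compound 2 is the weaker of the pair. The two differ in more than one place, so no single step can be read from them.

Compound 3 `CC(=O)c1cccc(OCc2ccc([N+](=O)[O-])cc2)c1` is the next compound in line, not yet measured in this assay. Relative to compound 2 the change is nitro in place of methyl on an aromatic carbon, on an aromatic carbon of a six-membered aromatic ring of carbon only, para to a large group. For the measured compounds named here, no measured pair in this set isolates this change, so the direction is open; the working expectation is a step of no more than the usual scatter, with the number for compound 3 estimated at 170 nM, within 60 nM to 500 nM. The expected step of a 1.2-fold higher number from compound 2 to compound 3 (0.08 log units; within the scatter) is thus small.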

Compound 3, half-maximal inhibitory concentration: 75.4 nM
Compound 3: the middle estimate sits 2.3-fold (0.35 log units) above what was measured; the range from low to high includes it.
By their numbers in this assay, from the lowest: compounds 1, 3 and 2 (each within the scatter of the next, the first and the last beyond it).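

In this assay the series now has its first step that can be read at a single place: nitro in place of methyl on an aromatic carbon, para to a large group, gives a 1.9-fold lower number from compound 2 to compound 3 (0.27 log units; within the scatter). This place on the ring thus carries either group, one heavy atom with no hydrogen-bond acceptors or three heavy atoms with two hydrogen-bond acceptors, with no difference beyond the scatter, so the two compounds cannot be put in order. No measurement at hand bears on why the two groups read alike.

Compound 1 differs from each of the other two compounds in more than one place, so the contributions of its chlorine and of the position of its acetyl group cannot be read separately. From the compounds shown here alone, how an amine, a carboxylic acid or a longer alkyl chain would read at this same place on the core of compound 2 remains open, as does whether the step from methyl to nitro would hold on the core of compound 1.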